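Estimating solubility for a new group on the carbonyl

The source may report more compounds than this note shows. Statements on the series, on what has been measured and on what is new or still open speak of the compounds shown alone.

Measured in a physicochemical assay for solubility; a higher number here means a more soluble compound, a lower number a less soluble compound:
Compound 1 `CN(C)c1ccc(C(=O)N2CCC(NS(=O)(=O)c3cc(S(=O)(=O)c4ccccc4)ccc3C(F)(F)F)CC2)cc1`: 50000 nM
Compound 2 `N#Cc1cccc(S(=O)(=O)N2CCC(NS(=O)(=O)c3cc(S(=O)(=O)c4ccccc4)ccc3C(F)(F)F)CC2)c1`: 6300 nM
Compound 3 `O=C(O)c1ccc(N2CCC(NS(=O)(=O)c3cc(S(=O)(=O)c4ccccc4)ccc3C(F)(F)F)CC2)cc1`: 25000 nM

Compound 1 and compound 3 sit together at the top of these numbers, within the scatter of each other, while compound 2 lies clearly lower. The next compound, compound 4 `CC(C)(C)OC(=O)N1CCC[C@@H]1C(=O)N1CCC(NS(=O)(=O)c2cc(S(=O)(=O)c3ccccc3)ccc2C(F)(F)F)CC1`, has not yet been measured. Its change from compound 1 is 1-(tert-butoxycarbonyl)pyrrolidin-2-yl in place of 4-(dimethylamino)phenyl on a carbonyl carbon with 1-(tert-butoxycarbonyl)pyrrolidin-2-yl taking the place of 4-(dimethylamino)phenyl on a carbonyl carbon. Within the data shown here, no measured step makes this exact swap. The nearest guides are two changes on the amine nitrogen in a ring, which replaced the whole (4-(dimethylamino)phenyl)carbonyl group. They gave a 7.9-fold lower number from compound 1 to compound 2 (0.90 log units; beyond the scatter) and a 2.0-fold lower number from compound 1 to compound 3 (0.30 log units; within the scatter) as their results. These suggest a modest drop at most, so the expected move is an estimated 2.5-fold lower number from compound 1 to compound 4 (0.40 log units; beyond the scatter) in this assay as a rough guide. Compound 4 is estimated at 20000 nM with 6000 nM to 60000 nM as the expected range.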

Compound 4, solubility: 25000 nM
Estimate against measurement, compound 4: 1.3-fold (0.10 log units) below, within the range that was stated.
By their numbers in this assay, from the lowest: compound 2; then compounds 3, 4 and 1 (each within the scatter of the next).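

Among these compounds, this is the first step that keeps the carbonyl on the amide-type nitrogen in a ring and changes only the group on the carbonyl carbon, and in this assay it gives a 2.0-fold lower number from compound 1 to compound 4 (0.30 log units; within the scatter). A 4-(dimethylamino)phenyl, with its six-membered aromatic ring of carbon only, and a 1-(tert-butoxycarbonyl)pyrrolidin-2-yl, with its five-membered non-aromatic ring and more heavy atoms, cannot be told apart here, so an aromatic ring on this carbonyl carbon is not needed for a number of this size. Nothing available explains why the two groups give such similar numbers.

Going by these compounds, it remains open whether the pyrrolidin-2-yl group with a free amine in place of the tert-butoxycarbonyl would give a similar number. The same holds for the opposite stereocentre and for a simple longer carbon chain on this carbonyl carbon.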